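The compounds below may be only part of what the source reports. "The series", "measured", "known", "first", "only" and "open" are said of these compounds alone.

Measured to date, all in a functional assay on HT-29 cells (Homo sapiens) for cytotoxicity, read by MTT assay, with a stated time of 72 h; a higher number here means that more compound is tolerated, a lower number that less compound is tolerated:
- compound 1, `CC(C)COC(=O)Nc1ccc([Se][Se]c2ccc(NC(=O)OCC(C)C)cc2)cc1`, compound 1 gives 77400 nM
- compound 2, `CCCCOC(=O)Nc1ccc([Se]C#N)cc1`, compound 2 gives 63700 nM
- compound 3, `CCCCCCOC(=O)Nc1ccc([Se][Se]c2ccc(NC(=O)OCCCCCC)cc2)cc1`, compound 3 gives 74200 nM

In this assay, among the compounds with values here, compound 2 sits within the scatter of both compound 1 and compound 3; the three numbers are not distinguishable from one another, and no single step between measured compounds is available to calibrate the effect of any structural change.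

Compound 4, `C=CCOC(=O)Nc1ccc([Se]C#N)cc1`, is not yet measured. It differs from compound 2 by vinyl in place of propyl on a saturated chain carbon bound to an oxygen next to a carbonyl group. Within the data shown here, no comparable step is measured, so the expectation is that the step from compound 2 to compound 4 stays within the scatter, in no particular direction: a 1.1-fold lower number from compound 2 to compound 4 (0.03 log units; within the scatter) is expected. Compound 4 is accordingly estimated at 60000 nM in this assay, with a range from 30000 nM to 130000 nM.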

Compound 4, concentration lethal to 50% of the cells: 72800 nM
The estimate for compound 4 lay 1.2-fold (0.08 log units) below the measured number, and the stated range covers the measured number.
By their numbers in this assay, from the lowest: compounds 2, 4, 3 and 1 (each within the scatter of the next).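

Within the data shown here, the first single-place comparison, in this assay, is a 1.1-fold higher number from compound 2 to compound 4 (0.06 log units; within the scatter), so the numbers for the two compounds cannot be told apart. At this position, on a saturated chain carbon bound to an oxygen next to a carbonyl group, vinyl in place of propyl is therefore tolerated, and the double bond has no readable effect on the number. No supporting data bear on this result.

As far as these compounds go, whether a longer chain, a phenyl ring or an amine at this position would give a step beyond the scatter remains open.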